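The source may report more compounds than this note shows. Statements on the series, on what has been measured and on what is new or still open speak of the compounds shown alone.

Measured compounds:
- compound 1, `O=C(NCc1ccc(S(=O)(=O)c2cc(F)cc(F)c2)cc1)N1Cc2ccncc2C1`: 16000 nM
- compound 2, `CC(=O)N1CCC(S(=O)(=O)c2ccc(CNC(=O)N3Cc4ccncc4C3)cc2)CC1`: 187000 nM
- compound 3, `CN1CCN(S(=O)(=O)c2ccc(CNC(=O)N3Cc4ccncc4C3)cc2)CC1`: 160000 nM

In a physicochemical assay for solubility, in phosphate buffer, with a stated time of 24 h, at pH 7.4, tested at 100 uM (on this read-out lower numbers stand for lower solubility and higher numbers for higher solubility), compound 1 has the lowest number of the three. Compound 4, `O=C(NCc1ccc(S(=O)(=O)N2CC3(CCOCC3)C2)cc1)N1Cc2ccncc2C1`, has not yet been measured. It differs from compound 1 in one place: a group of 9 heavy atoms (7 carbon, 1 nitrogen, 1 oxygen; one four-membered non-aromatic ring with 1 hetero atom, one six-membered non-aromatic ring with 1 hetero atom) in place of a group of 8 heavy atoms (6 carbon, 2 fluorine; one six-membered aromatic ring of carbon only), on a sulfonyl sulfur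

For the measured compounds named here, two measured steps bear on this change. Both of them also replace the 3,5-difluorophenyl on the sulfonyl sulfur with a non-aromatic ring group. The step of a 12-fold higher number from compound 1 to compound 2 (1.07 log units; beyond the scatter) and the step of a 10-fold higher number from compound 1 to compound 3 (1.00 log units; beyond the scatter) point the same way and were both beyond the scatter. Compound 4 carries a non-aromatic ring group with one hydrogen-bond acceptor at the same place, so a higher number is expected in this assay, of about the same size as these two steps. Compound 4 is therefore expected to give 110000 nM, with a range from 35000 nM to 220000 nM. This expectation corresponds to the step of a 6.9-fold higher number from compound 1 to compound 4 (0.84 log units; beyond the scatter).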

Compound 4, solubility: 272000 nM
The estimate for compound 4 lay 2.5-fold (0.39 log units) below the measured number; the measured number lies above the stated range.
By their numbers in this assay, from the lowest: compound 1; then compounds 3, 2 and 4 (each within the scatter of the next).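

In this assay the group entering on the sulfonyl sulfur gives a 17-fold higher number from compound 1 to compound 4 (1.23 log units; beyond the scatter) and is a third non-aromatic ring group to stand well clear of the 3,5-difluorophenyl of compound 1, now with one four-membered and one six-membered ring. Its difference from the earlier replacements is small, with a 1.7-fold higher number from compound 3 to compound 4 (0.23 log units; within the scatter) and a 1.5-fold higher number from compound 2 to compound 4 (0.16 log units; within the scatter) both within the scatter, so this read-out does not separate these three groups despite their different rings and atoms. Nothing given here accounts for the size of these steps.

Going by these compounds, each step away from compound 1 removes the aromatic ring and both fluorines together, so the share of each remains open. A plain phenyl, a pyridyl or an open-chain diethylamino group on the sulfonyl sulfur would help to separate them.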